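The source may report more compounds than this note shows. Statements on the series, on what has been measured and on what is new or still open speak of the compounds shown alone.

Measured compounds:
Compound 1, `COc1cc2ncnc(Nc3ccc(Br)cc3)c2cc1OCCCCC(=O)Nc1ccc(S(N)(=O)=O)cc1`, in a functional assay on A549 cells (Homo sapiens) for antiproliferative activity, read by MTT assay, with a stated time of 72 h (on this read-out lower numbers stand for stronger inhibition and higher numbers for weaker inhibition), gives > 40000 nM, which is a limit of the assay and not a number.
Compound 2, `COc1cc2ncnc(Nc3ccc(OC(F)(F)F)cc3)c2cc1OCCCCC(=O)Nc1ccc(S(N)(=O)=O)cc1`, in this assay gives > 40000 nM, again a limit and not a number.

Compound 2 therefore stands at the top of the range shown, with no readable value of its own; the single measured step, a step that the two limits leave unreadable from compound 1 to compound 2, cannot be sized because of the limit of > 40000 nM in this assay, at which 2 of the 2 values shown sit.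

Compound 3 is `COc1cc2ncnc(Nc3cc(F)c(F)c(F)c3)c2cc1OCCCCC(=O)Nc1ccc(S(N)(=O)=O)cc1`. It differs from compound 2 by 3,4,5-trifluorophenyl in place of 4-(trifluoromethoxy)phenyl on a nitrogen on an aromatic ring.

Among the measured compounds shown here, no measured step bears on this change with a readable size, so no direction is expected for it; the only comparison available, the step from compound 1 to compound 2, gives nothing beyond the fact that both ends sit at the limit. Compound 3 is therefore expected to remain at or beyond the limit as well, with the step that the limit leaves unreadable from compound 2 to compound 3 expected to be unreadable. The estimate for compound 3 in this assay is 60000 nM, within 20000 nM to 200000 nM.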

Compound 3, half-maximal inhibitory concentration: > 40000 nM
Compound 3: a limit, no number; the forecaster's own chance of this, stated with the estimate: 85%; the middle value does not contradict the limit.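

No new step can be read: compound 3 sits at the same assay limit as compound 1 and compound 2, so all steps among them stay unreadable: the limit of > 40000 nM in this assay, at which 3 of the 3 values shown sit.

The compounds shown leave open whether 4-bromophenyl, 4-(trifluoromethoxy)phenyl and 3,4,5-trifluorophenyl differ at all in this assay.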